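Cytotoxicity limits and the trifluoromethyl analogue of compound 3

The source may hold more compounds than are shown below. What is called first, only, known or untested is meant among the compounds shown, and "the series" means these compounds.

Compound 1 `CNC(=O)c1cc2ncn(-c3ccc(C#N)cc3)c2cc1Oc1c(C)cc(/C=C/C#N)cc1C`: > 890000 nM
Compound 2 `CNC(=O)c1cc2ncn(-c3ccc(C#N)cc3)c2cc1Oc1c(C)cc(CCC#N)cc1C`: > 890000 nM
Compound 3 `Cc1cc(CCC#N)cc(C)c1Oc1cc(Nc2ccc(C#N)cc2)c(N)cc1N`: > 25000 nM

All three entries come from an ADME assay on TZM cells (Homo sapiens) for cytotoxicity, read by XTT assay, with a stated time of 4 days (a lower number here means that less compound is tolerated, a higher number that more compound is tolerated), and each one is a limit, not a number. Compound 3 stands only at its limit of > 25000 nM. Compound 1 and compound 2 share a different limit, (the limit of > 890000 nM in this assay, at which 2 of the 3 values shown sit).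

Compound 4 `Cc1cc(CCC#N)cc(C)c1Oc1cc(Nc2ccc(C#N)cc2)c(N)cc1C(F)(F)F` carries trifluoromethyl in place of amino on an aromatic carbon. This carbon is ortho to a large group and para to a (4-cyanophenyl)amino group.

Among the compounds with values here, the one measured step, a step that the two limits leave unreadable from compound 1 to compound 2, concerns 2-cyanoethyl in place of 2-cyanoethenyl on an aromatic carbon. It is a different change and gives no size to carry over. The expectation therefore rests on compound 3 alone, with its limit of > 25000 nM. The expected step in this assay is a step that the limit leaves unreadable from compound 3 to compound 4, which means none beyond the scatter. The estimate for compound 4 is 30000 nM, expected to fall between 8000 nM and 100000 nM.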

Compound 4, half-maximal cytotoxic concentration: > 7100 nM
Compound 4 gave a limit, no number; the forecaster's own chance of this, stated with the estimate: 60%; the middle value lies beyond the limit too.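

Compound 3 and compound 4 both stand only at limits in this assay, so no step can be read between them. The compounds shown leave open where any of the four half-maximal cytotoxic concentrations lies, and whether trifluoromethyl in place of amino changes it at all.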